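The compounds below may be only part of what the source reports. "The series", "measured", "known", "first", "only" and "open" are said of these compounds alone.

Measured compounds:

- compound 1, `O=S(=O)(Nc1cccc(Cl)c1)c1ccc(-c2cnc(C3CC3)o2)cc1`, gives 477 nM in a functional assay on cells (leukaemia cell line, Homo sapiens) for inhibition, read by sulforhodamine B assay, with a stated time of 48 h; on this read-out higher numbers stand for weaker inhibition of growth and lower numbers for stronger inhibition of growth
- compound 2, `Cc1ccc(NS(=O)(=O)c2ccc(-c3cnc(C4CC4)o3)cc2)cc1C`, gives 420 nM in this assay

Compound 2 stands at the lowest of the two numbers, with compound 1 nearest; the step of a 1.1-fold lower number from compound 1 to compound 2 (0.06 log units; within the scatter) separates them, so the two cannot be put in order. Compound 3, `O=S(=O)(Nc1ccc(I)c(Cl)c1)c1ccc(-c2cnc(C3CC3)o2)cc1`, has not yet been measured. It differs from compound 2 by 3-chloro-4-iodophenyl in place of 3,4-dimethylphenyl on a sulfonamide nitrogen. Among the measured compounds shown here, the one measured step that bears on this change is a 1.1-fold lower number from compound 1 to compound 2 (0.06 log units; within the scatter), which also exchanged the group on the sulfonamide nitrogen and stayed within the scatter. Compound 3 keeps a chlorine on that ring, as compound 1 does, and adds an iodine. On this basis no step beyond the scatter is expected in this assay for compound 3, perhaps a small move toward a lower number, as a 1.2-fold lower number from compound 2 to compound 3 (0.08 log units; within the scatter). Compound 3 is therefore estimated at 350 nM, within 150 nM to 900 nM.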

Compound 3, concentration for 50% growth inhibition: 1010 nM
Estimate against measurement, compound 3: 2.9-fold (0.46 log units) below; measured number outside the range, above it.
By their numbers in this assay, from the lowest: compounds 2 and 1 (each within the scatter of the next); then compound 3.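

In this assay, the group on the sulfonamide nitrogen turns out to matter: a 2.4-fold higher number from compound 2 to compound 3 (0.38 log units; beyond the scatter) lies beyond the scatter, which the earlier exchange at this place did not. The iodo group alone is enough for a modest loss of growth inhibition, as the chlorine is kept and iodo in place of hydrogen on an aromatic carbon gives a 2.1-fold higher number from compound 1 to compound 3 (0.33 log units; beyond the scatter). Nothing measured here explains this loss.

The compounds shown leave open whether this loss belongs to iodo in particular or would also come with another group on that carbon, such as fluoro, methoxy or a longer alkyl chain. They also leave open how an amine or a carboxylic acid on this ring would read in the same assay.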